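The source may report more compounds than this note shows. Statements on the series, on what has been measured and on what is new or still open speak of the compounds shown alone.

Measured so far:
- compound 1, `COCCNC(=C\C(=O)/C=C/c1ccc(O)cc1)/C=C/c1ccc(O)cc1`: 82.5%
- compound 2, `O=C(/C=C(/C=C/c1ccc(O)cc1)NCCO)/C=C/c1ccc(O)cc1`: 93.4%

Both compounds were tested in an ADME assay on CHO-K1 cells (Cricetulus griseus) for activation, read by fluorescence, tested at 1 uM; a higher number here means a weaker effect of the compound at the concentration tested, a lower number a stronger effect. Compound 1 gives 82.5%, and compound 2 gives 93.4%. Within the data shown here, of the two, compound 2 stands highest, which in this assay means the weaker effect; the single step connecting them is a number 10.9 percentage points higher from compound 1 to compound 2 (beyond the scatter), and it goes beyond the scatter.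

Compound 3, `COCCCNC(=C\C(=O)/C=C/c1ccc(O)cc1)/C=C/c1ccc(O)cc1`, has not yet been measured in this assay. It differs from compound 2 in one place: methoxymethyl in place of hydroxy on a saturated chain carbon, two bonds along the chain from an amine nitrogen. This touches the same end of the chain on the amine nitrogen that changed between compound 1 and compound 2, only in the opposite sense: where that step took the methyl off the oxygen and raised the number, this one puts a methyl-bearing oxygen back, one carbon further out. Among the measured compounds shown here, the only step that bears on it is therefore the one from compound 1 to compound 2, and its size suggests a step back down of roughly the same size for compound 3, expected as a number 9.4 percentage points lower from compound 2 to compound 3 (within the scatter). Compound 3 is accordingly estimated at 84%, with a range from 72% to 95%.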

Compound 3, a percentage reported as activity, at one concentration (the size of the read-out at that concentration, not a potency): 99.8%
Beside the measured number, compound 3's estimate is 15.8 percentage points below it; measured number above the stated range.
By their numbers in this assay, from the lowest: compound 1; then compounds 2 and 3 (each within the scatter of the next).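

In this assay, putting methoxymethyl in place of hydroxy on a saturated chain carbon, two bonds along the chain from an amine nitrogen, gives a number 6.4 percentage points higher from compound 2 to compound 3 (within the scatter), so at this position the swap from the 2-hydroxyethyl chain to the 3-methoxypropyl chain makes no readable difference. Going from 2-methoxyethyl to 3-methoxypropyl on the same amine nitrogen gives a number 17.3 percentage points higher from compound 1 to compound 3 (beyond the scatter), which shows that a methyl on the chain oxygen does not by itself go with the lower number: compound 3 carries that methyl as well, and among these three only compound 1, with the 2-methoxyethyl chain, stands apart. No measurement at hand explains why the 2-methoxyethyl and 3-methoxypropyl chains differ in this way.

The compounds shown leave open whether a longer chain ending in methoxy would stay level with compound 3 or move elsewhere. They also leave open what an amine or a carboxylic acid would do in place of the methoxy group on this chain.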